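This account rests on a few compounds, and the source may have more. Where it says the series, first, only, none or still open, it means among the compounds named here.

Compound 1 `CN1CCN(CCCCn2c3c(c4ccccc42)C(=O)c2c[n+]([O-])c4ccccc4c2C3=O)CC1` carries the shared core with a 4-(4-methylpiperazin-1-yl)butyl chain on the aromatic nitrogen. In a functional assay on SH-SY5Y cells (Homo sapiens) for cytotoxicity, read by MTT assay, with a stated time of 72 h (on this read-out lower numbers stand for stronger inhibition and higher numbers for weaker inhibition), compound 1 gives 100 nM, the lowest of the two numbers in the set. Compound 3 `CC1(C)OC[C@H](Cn2cc(Cn3c4c(c5ccccc53)C(=O)c3c[n+]([O-])c5ccccc5c3C4=O)nn2)O1` gives 820 nM in this assay; the gap from compound 3 to compound 1 lies beyond the scatter. Compound 2 `CC1(C)O[C@@H](CO)[C@H](Cn2cc(Cn3c4c(c5ccccc53)C(=O)c3c[n+]([O-])c5ccccc5c3C4=O)nn2)O1` gives > 1000 nM in this assay, which is a limit of the assay and not a number. Compound 2 thus reaches only (the limit of > 1000 nM in this assay, at which 1 of the 3 values shown sits), so no number is known for compound 2 in this assay. For the measured compounds named here, the one step within the set, an at least 1.2-fold lower number from compound 2 to compound 3 (0.08 log units; that floor lies within the scatter), concerns a change on a saturated ring carbon and says nothing about the chain on the aromatic nitrogen.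

Compound 4 `CN(C)CCCCn1c2c(c3ccccc31)C(=O)c1c[n+]([O-])c3ccccc3c1C2=O` differs from compound 1 as follows: dimethylamino in place of 4-methylpiperazin-1-yl on a saturated chain carbon, four bonds along the chain from an aromatic nitrogen. Going by the values given here, no measured step covers this kind of change, so the expectation rests on compound 1 alone, with its 100 nM in this assay as the anchor. The step from compound 1 to compound 4 is expected to be a 1.5-fold higher number from compound 1 to compound 4 (0.18 log units; within the scatter), not beyond the scatter. Compound 4 is therefore estimated at 150 nM in this assay, within 60 nM to 400 nM.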

Compound 4, half-maximal inhibitory concentration: 250 nM
The estimate for compound 4 lay 1.7-fold (0.22 log units) below the measured number; the range from low to high includes it.
By their numbers in this assay, from the lowest: compound 1; then compound 4; then compound 3. At a limit, above all of these: compound 2.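

At the saturated chain carbon, four bonds along the chain from an aromatic nitrogen, the series now has its first step that can be read as a clear change: in this assay, dimethylamino in place of 4-methylpiperazin-1-yl gives a 2.5-fold higher number from compound 1 to compound 4 (0.40 log units; beyond the scatter), which is modest but beyond the scatter. On this single pair, the six-membered ring of compound 1 can be given up at a modest cost, and compound 4 still gives a number rather than a limit. Nothing at hand accounts for the size of this step.

Still open, from the compounds shown here alone, is how a chain ending in morpholin-4-yl, piperidin-1-yl or a carboxylic acid would compare with these two amines. A shorter or longer chain carrying 4-methylpiperazin-1-yl or dimethylamino also remains to be placed against compound 1 and compound 4.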